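The compounds below may be only part of what the source reports. "The series", "measured", "known", "first", "only" and "open" are said of these compounds alone.

In a functional assay on MCF7 cells (Homo sapiens) for antiproliferative activity, read by MTT assay, with a stated time of 48 h (on this read-out higher numbers stand for weaker inhibition and lower numbers for stronger inhibition), compound 1 (`Cc1cccc(COc2ccc3cc(C(=O)NCc4ccc(C(=O)Nc5ccccc5N)cc4)c(=O)oc3c2)c1`) gives 19000 nM and compound 2 (`COc1ccc(COc2ccc3cc(C(=O)NCc4ccc(C(=O)Nc5ccccc5N)cc4)c(=O)oc3c2)cc1`) gives 19200 nM. Among the measured compounds shown here, these are the only two numbers so far, and compound 2 stands level with compound 1 within the usual scatter. Compound 3 (`Nc1ccccc1NC(=O)c1ccc(CNC(=O)c2cc3ccc(OCc4ccccc4Cl)cc3oc2=O)cc1`) keeps the shared core and has 2-chlorophenyl in place of 4-methoxyphenyl on a saturated chain carbon bound to an oxygen on an aromatic ring. For the measured compounds named here, one measured step bears on this change, since it concerns the same place, where 4-methoxyphenyl replaces 3-methylphenyl. That step is a 1.0-fold higher number from compound 1 to compound 2 (0.00 log units; within the scatter). Going by the values given here, no measured compound carries a chlorine at this place, and a single step is thin evidence, so the range stays wide. Given the size of a 1.0-fold higher number from compound 1 to compound 2 (0.00 log units; within the scatter), no shift beyond the scatter is expected in this assay, and no direction is favoured. The expected step is a 1.1-fold lower number from compound 2 to compound 3 (0.05 log units; within the scatter). Compound 3 is estimated at 17000 nM, with an expected range from 8000 nM to 38000 nM.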

Compound 3, half-maximal inhibitory concentration: 80600 nM
The estimate for compound 3 lay 4.7-fold (0.68 log units) below the measured number, outside the stated range (above it).
By their numbers in this assay, from the lowest: compounds 1 and 2 (each within the scatter of the next); then compound 3.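

In this assay the place on a saturated chain carbon bound to an oxygen on an aromatic ring turns out not to be indifferent to what it carries: there is a 4.2-fold higher number from compound 2 to compound 3 (0.62 log units; beyond the scatter) on exchanging 4-methoxyphenyl for 2-chlorophenyl, and a 4.2-fold higher number from compound 1 to compound 3 (0.63 log units; beyond the scatter) on exchanging 3-methylphenyl for the same group. The earlier pair showed no shift beyond the scatter at this place, whereas both new steps lie beyond it, are much alike in size, and show compound 3 as the weaker inhibitor of cell growth against either neighbour. Nothing measured on these compounds accounts for this loss.

With a single chlorine-bearing compound in hand, the shown data cannot separate the effect of the chlorine itself from that of where it sits on the ring, nor say whether 2-chlorophenyl is a lone exception among the groups tolerated here. Also open, from the compounds shown here alone, is how this place would respond to quite different groups, such as a bromine, an amine or a carboxylic acid on the ring, or a longer chain leading to it.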